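Chloro for Hydrogen: Weighing a Repeated Change

The compounds below may be only part of what the source reports. "The series", "measured", "known", "first", "only" and "open" are said of these compounds alone.

Of the compounds shown here, three have been measured in a functional assay on KG-1 cells (Homo sapiens) for cytotoxicity, read by luminescence and CellTiter-Glo, with a stated time of 3 days; a lower number here means a stronger inhibitor, a higher number a weaker inhibitor. Compound 2 `N#Cc1ccc(NC(=O)c2cc(Cl)ccc2O)cc1` gives 1860 nM. Compound 1 `N#Cc1ccc(NC(=O)c2cc(Cl)ccc2O)c(Cl)c1` differs from it in one place, (chloro in place of hydrogen on an aromatic carbon), and in this assay compound 1 gives 860 nM, so that a 2.2-fold lower number from compound 2 to compound 1 (0.34 log units; beyond the scatter). Compound 3 `O=C(Nc1cccc(C(F)(F)F)c1)c1cc(F)ccc1O` stands on a different core, and the difference between the two cores is not broken down here. In this assay compound 3 gives 1010 nM, a number within the scatter of both compound 1 and compound 2.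

Compound 4 `O=C(Nc1ccc(Cl)c(C(F)(F)F)c1)c1cc(F)ccc1O` has not been measured. It arises from compound 3 by chloro in place of hydrogen on an aromatic carbon. For the measured compounds named here, this is the same kind of change as the one from compound 2 to compound 1, not the same change: in compound 4 the chloro enters ortho to a trifluoromethyl group and para to a large group, whereas in compound 1 it enters ortho to a large group and meta to a cyano group. Going by the values given here, the only guide is the single step of a 2.2-fold lower number from compound 2 to compound 1 (0.34 log units; beyond the scatter), observed on another core. Compound 4 is expected to give a lower number than compound 3, a 1.8-fold lower number from compound 3 to compound 4 (0.26 log units; within the scatter), a step kept a little smaller than the earlier one, which rests on one instance alone. The estimate for compound 4 in this assay is 550 nM, with a range from 250 nM to 1200 nM.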

Compound 4, half-maximal inhibitory concentration: 540 nM
For compound 4 the middle estimate is 1.0-fold (0.01 log units) above the measured one; low and high end bracket the measured number.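

In this assay the replacement of hydrogen by chloro on the core of compound 3 gives a 1.9-fold lower number from compound 3 to compound 4 (0.27 log units; within the scatter), a step that stands within the scatter when taken alone but matches the earlier one in direction and closely in size: the same change on two cores in this assay, a 2.2-fold lower number (0.34 log units; beyond the scatter) from compound 2 to compound 1 and a 1.9-fold lower number (0.27 log units; within the scatter) from compound 3 to compound 4, 1.2-fold (0.06 log units) apart, within the scatter of two such steps. The two steps therefore give no sign that the change behaves differently on the two cores, and the earlier step can fairly serve as a guide to the later one in this small set. For the compounds shown here, this does not show that the change will transfer in general, since it rests on only two pairs, one of whose steps cannot by itself be told apart from scatter, and since the chloro enters a different surrounding in each pair, so that the effect of the core is not separated from that of the place on the ring.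

The compounds shown leave open whether a group other than chloro, such as bromo, methyl, methoxy or an amine, would give a step of similar size at the place ortho to a trifluoromethyl group. They also leave open how the step would look on further cores, including one carrying a carboxylic acid.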